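The source may hold more compounds than are shown below. What is called first, only, known or untested is meant among the compounds shown, and "the series" means these compounds.

Working notes on the series in an assay on isolated protein for inhibition of protein arginine N-methyltransferase 6 (Homo sapiens); a higher number here means a weaker inhibitor, a lower number a stronger inhibitor.

Three compounds have been run. Compound 1 `CNCCN1CCCC1` gives 1900 nM in this assay. Compound 2 `CCC(c1ccc(OC)cc1)N(C)CCN` returns only a limit of the assay, > 25000 nM, not a number. Compound 3 `C[C@@H](N)C(=O)NCc1cccnc1Oc1ccc(F)cc1F` is recorded as "not active" (no number reported) in this assay, with no number attached. On the numbers shown, compound 3 therefore has no single value to stand on; the nearest reference point is the limit of > 25000 nM in this assay, at which 1 of the 3 values shown sits, and compound 3 cannot be placed against compound 1 beyond saying that compound 1 carries a measured number and compound 3 does not.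

Compound 4 `NC1(C(=O)NCc2cccnc2Oc2ccc(F)cc2F)CC1` differs from compound 3 by 1-aminocyclopropyl in place of 1-aminoethyl on a carbonyl carbon. Among the measured compounds shown here, no measured step between two compounds exists to size this change. Given that compound 3 shows no measurable inhibition in this assay, the expectation for compound 4 is no step beyond the scatter, with the result most likely again a limit rather than a number. Compound 4 is estimated at 30000 nM, in the range 8000 nM to 100000 nM.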

Compound 4, half-maximal inhibitory concentration: "not active" (no number reported)
Compound 4 has no reported number here; the estimate stays without a comparison.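

Compound 3 and compound 4 both carry no number in this assay, and no step can be read between them. The compounds shown leave open what 1-aminocyclopropyl in place of 1-aminoethyl does on an analogue with a measurable value.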